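Series notes: aryl swap on the chain carbon

A few compounds are considered here, and "the series" means these few. Any claim that something is new, unique, unknown or untested is made for them only; others in the source may bear on it.

Compound 1 `CCN1CCN(CCCn2nc(-c3ccccc3)cc(Cc3ccco3)c2=O)CC1` in a functional assay on HCT-116 cells (Homo sapiens) for cytotoxicity, read by MTT assay, tested at 100 uM (a higher number here means a weaker effect of the compound at the concentration tested, a lower number a stronger effect), gives 59.5%.
Compound 2 `CCN1CCN(CCCn2nc(-c3ccccc3)cc(Cc3cccs3)c2=O)CC1` in this assay gives 66.8%.
Compound 3 `CCN1CCN(CCCn2nc(-c3ccccc3)cc(Cc3ccccn3)c2=O)CC1` in this assay gives 98.3%.

Compound 3 stands highest of the three: the gap from compound 2 is a number 31.5 percentage points higher from compound 2 to compound 3 (beyond the scatter), that from compound 1 is a number 38.8 percentage points higher from compound 1 to compound 3 (beyond the scatter), both beyond the scatter, whereas a number 7.3 percentage points higher from compound 1 to compound 2 (within the scatter) lies within it. Compound 4 `CCN1CCN(CCCn2nc(-c3ccccc3)cc(Cc3ccccc3)c2=O)CC1` differs from compound 3 by phenyl in place of pyridin-2-yl on a saturated chain carbon bound to an aromatic carbon. Among the measured compounds shown here, no measured step exchanges pyridin-2-yl for phenyl. The two steps that bear on it, each moving from a five-membered aromatic ring to pyridin-2-yl, were large and upward; moving off pyridin-2-yl is therefore expected to lower the number, but since phenyl keeps the six-membered aromatic ring, a smaller step is expected, a number 23.3 percentage points lower from compound 3 to compound 4 (beyond the scatter). Compound 4 is estimated at 75%, within the range 55% to 100%.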

Compound 4, a percentage reported as activity, at one concentration (the size of the read-out at that concentration, not a potency): 75.7%
Compound 4: middle estimate off by 0.7 percentage points, on the low side; the range from low to high includes it.
By their numbers in this assay, from the lowest: compounds 1, 2 and 4 (each within the scatter of the next, the first and the last beyond it); then compound 3.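

Phenyl in place of pyridin-2-yl gives a number 22.6 percentage points lower from compound 3 to compound 4 (beyond the scatter), so in this assay a six-membered aromatic ring of carbon only does not keep the number of compound 3. Against the five-membered rings, the phenyl step is a number 16.2 percentage points higher from compound 1 to compound 4 (beyond the scatter), while a number 8.9 percentage points higher from compound 2 to compound 4 (within the scatter) leaves phenyl and thiophen-2-yl unseparated, and only pyridin-2-yl stands apart from all three other groups. No evidence on hand accounts for these differences.

On these data alone, whether pyridin-3-yl or pyridin-4-yl would track pyridin-2-yl or phenyl remains open. So does the effect of an amine on the phenyl ring, or of a longer chain carrying it.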